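Chloro for methyl at two different places in a sulfonamide series

The source may hold more compounds than are shown below. What is called first, only, known or untested is meant among the compounds shown, and "the series" means these compounds.

Three compounds were measured in a functional assay on J774 cells (Mus musculus) for cytotoxicity, read by resazurin assay, with a stated time of 72 h; on this read-out lower numbers stand for stronger inhibition and higher numbers for weaker inhibition. Compound 1 `O=S(=O)(Nc1cccc(CO)c1)c1ccc(-c2ccc(Cl)cc2)cc1` gives 2500 nM, compound 2 `Cc1ccc(-c2ccc(S(=O)(=O)Nc3cccc(CO)c3)cc2)cc1` gives 1200 nM, and compound 3 `Cc1c(CO)cccc1NS(=O)(=O)c1ccc(-c2ccc(Br)cc2)cc1` gives 750 nM. Compound 1 differs from compound 2 by chloro in place of methyl on an aromatic carbon, a change that produced a 2.1-fold higher number from compound 2 to compound 1 (0.32 log units; beyond the scatter). The difference between the cores of compound 2 and compound 3 is not broken down here. Compound 4 `O=S(=O)(Nc1cccc(CO)c1Cl)c1ccc(-c2ccc(Br)cc2)cc1` differs from compound 3 by chloro in place of methyl on an aromatic carbon, the same kind of change, but at a different place: in compound 4 the chloro sits ortho to a hydroxymethyl group and ortho to a large group, whereas in compound 1 it sits para to a large group. Resting on the earlier step in this assay, a step of a 1.6-fold higher number from compound 3 to compound 4 (0.20 log units; within the scatter) is expected. Compound 4 is therefore estimated at 1200 nM, between 500 nM and 3000 nM.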

Compound 4, half-maximal inhibitory concentration in the J774 assay: 5000 nM
Compound 4: the middle estimate sits 4.2-fold (0.62 log units) below what was measured, and the stated range ends below it.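

In the J774 assay compound 3 gives 750 nM and compound 4 gives 5000 nM. In the J774 assay chloro in place of methyl gave a 6.7-fold higher number from compound 3 to compound 4 (0.82 log units; beyond the scatter), and this step did not keep the size of the earlier one: the same change on two cores in the J774 assay, a 2.1-fold higher number (0.32 log units; beyond the scatter) from compound 2 to compound 1 and a 6.7-fold higher number (0.82 log units; beyond the scatter) from compound 3 to compound 4, 3.2-fold (0.51 log units) apart, beyond the scatter of two such steps. Both steps run the same way, so direction held across these two pairs while size did not, but the chloro also sits at a different place in compound 4 than in compound 1, and these pairs cannot separate the effect of place from that of core. In a physicochemical assay for solubility, read by HPLC, in simulated intestinal fluid, measured as thermodynamic solubility, with a stated time of 24 h (a higher number here means a more soluble compound, a lower number a less soluble compound), compound 3 gives 12 ug/mL and compound 4 gives 14 ug/mL. In the physicochemical assay the same change gave a 1.2-fold higher number from compound 3 to compound 4 (0.07 log units; within the scatter).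

On these data alone, what remains open is how an amine or a methoxy group would read on that same aromatic carbon. Also open, as far as these compounds go, is whether the step survives when a carboxylic acid stands in place of the hydroxymethyl group.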